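From chloro to methyl on an aromatic carbon

A few compounds are considered here, and "the series" means these few. Any claim that something is new, unique, unknown or untested is made for them only; others in the source may bear on it.

Compound 1 `Cc1ccc(-c2nn(-c3ccccc3)cc2CNc2ccc(Br)cc2)cc1`, compound 2 `Cc1ccc(-c2nn(-c3ccccc3)cc2CNc2ccc(C(F)(F)F)cc2)cc1` and compound 3 `Cc1ccc(-c2nn(-c3ccccc3)cc2CNc2ccc(Cl)cc2)cc1` were tested in an ADME assay on BHK-21 cells (Mesocricetus auratus) for cytotoxicity, read by MTT assay, with a stated time of 72 h; on this read-out higher numbers stand for lower toxicity in this test and lower numbers for higher toxicity in this test.
Compound 1 gives the limit > 100000 nM.
Compound 2 gives 88000 nM.
Compound 3 gives the limit > 100000 nM.

Compound 3 thus stands at the limit, where (the limit of > 100000 nM in this assay, at which 2 of the 3 values shown sit). The steps of an at least 1.1-fold higher number from compound 2 to compound 3 (0.05 log units; that floor lies within the scatter) and a step that the two limits leave unreadable from compound 1 to compound 3 bear on the next change; they show that exchanging the group on this aromatic carbon has hardly moved the read-out. Compound 4 `Cc1ccc(NCc2cn(-c3ccccc3)nc2-c2ccc(C)cc2)cc1` differs from compound 3 by methyl in place of chloro on an aromatic carbon. Within the data shown here, no measured step brings in a methyl, so the expectation rests on all three compounds sitting at or near the limit. The expected step is a step that the limit leaves unreadable from compound 3 to compound 4, within the scatter. Compound 4 is therefore estimated at 120000 nM, ranging from 60000 nM to 250000 nM, most likely reported only as a limit.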

Compound 4, half-maximal cytotoxic concentration: > 100000 nM
Compound 4: no number, only a limit; the forecaster's own chance of this, stated with the estimate: 75%; the middle value is on the limit's open side.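

In this assay, among these compounds, methyl is the first group on this aromatic carbon that is not a halogen or trifluoromethyl, yet the result matches those for bromo and chloro: the limit of > 100000 nM in this assay, at which 3 of the 4 values shown sit. Among the compounds shown here, the one readable step, an at least 1.1-fold higher number from compound 2 to compound 4 (0.05 log units; that floor lies within the scatter), shows no clear separation from trifluoromethyl, and the steps from compound 1 and compound 3 to compound 4 cannot be read.

On these data alone, how far the true values of compound 1, compound 3 and compound 4 lie past the limit remains open. So does whether an amine or a carboxylic acid on this carbon would give a clearly lower number.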